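The compounds below may be only part of what the source reports. "The series", "measured", "known", "first", "only" and "open" are said of these compounds alone.

Measured so far:
compound 1 `COc1ccc(N2CCN(Cc3csc(N)c3C(=O)c3ccc(Cl)cc3)CC2)cc1`: 0%
compound 2 `Nc1scc(CN2CCN(c3ccncc3)CC2)c1C(=O)c1ccc(Cl)cc1`: 1%

In an assay on CHO cells for displacement of a labelled ligand from adenosine receptor A1 (Homo sapiens), read by scintillation counting, with a stated time of 120 min, tested at 10 uM (a lower number here means less inhibition, a higher number more inhibition at the concentration tested (going by the name of the read-out)), compound 2 gives 1%; compound 1 gives 0%, and the two lie within the scatter of each other, so compound 2 stands apart from nothing. Compound 3 `Nc1scc(CN2CCN(c3cc(F)cc(F)c3)CC2)c1C(=O)c1ccc(Cl)cc1` is not yet measured. It differs from compound 2 as follows: 3,5-difluorophenyl in place of pyridin-4-yl on an amine nitrogen in a ring. Within the data shown here, the only measured step touching this ring nitrogen is a number 1 percentage points higher from compound 1 to compound 2 (within the scatter), which shows that swapping the aromatic group there left this assay flat. The step is therefore expected to be a number 1 percentage points higher from compound 2 to compound 3 (within the scatter), with no change beyond the scatter. Compound 3 is estimated at 2%, between -8% and 12%.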

Compound 3, a percentage reported as inhibition, at one concentration (the size of the read-out at that concentration, not a potency): 0%
The estimate for compound 3 lay 2 percentage points above the measured number; low and high end bracket the measured number.
By their numbers in this assay, from the lowest: compounds 1, 3 and 2 (each within the scatter of the next).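

In this assay, 3,5-difluorophenyl on the ring nitrogen gives a number 1 percentage points lower from compound 2 to compound 3 (within the scatter) and no change at the digits printed from compound 1 to compound 3 (within the scatter), so all three aromatic groups tested at this position lie within the scatter of one another. The step from pyridin-4-yl removes the ring hetero atom and its counted hydrogen-bond acceptor, and adds two fluorines, with no reading beyond the scatter. No available evidence bears on this result.

Going by these compounds, whether any group on this ring nitrogen can move the number beyond the scatter remains open. A benzyl group, an acetyl group or a short alkyl chain there would test this beyond directly attached six-membered aromatic rings.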